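The source may hold more compounds than are shown below. What is called first, only, known or untested is meant among the compounds shown, and "the series" means these compounds.

Series notes. Compound 3 `COc1ccccc1S(=O)(=O)/C=C/c1cccnc1` is the reference point here. In an ADME assay on BV-2 cells (Mus musculus) for cytotoxicity, with a stated time of 24 h, tested at 10 uM (a lower number here means a stronger effect, a higher number a weaker effect of the compound at the concentration tested), compound 3 gives 100%. Compound 1 `COc1ccccc1S(=O)(=O)/C=C/c1ccccn1` gives 100% and compound 2 `COc1ccc(S(=O)(=O)/C=C/c2ccc(Cl)cn2)cc1` gives 100%, so compound 3 stands level with both at the digits shown, nearest to compound 1 and furthest from compound 2, yet without any gap beyond the scatter. Going by the values given here, the only single-point step available is no change at the digits printed from compound 1 to compound 3 (within the scatter), and it leaves the read-out untouched.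

Compound 4 `COc1ccccc1S(=O)(=O)/C=C/c1cccnc1Cl` differs from compound 3 by chloro in place of hydrogen on an aromatic carbon. Among the compounds with values here, no measured step introduces a chloro in a single move; compound 2 does carry a chloro on its ring and gives 100%, the same level as compound 3, but compound 2 differs from compound 3 in more than one place and so supplies no direct step. Within the data shown here, with all three measured compounds at one level and the one measured step within the scatter, no step beyond the scatter is expected for no change at the digits printed from compound 3 to compound 4 (within the scatter). Compound 4 is therefore estimated at 100%, with an expected range from 88% to 106%.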

Compound 4, a percentage reported as activity, at one concentration (the size of the read-out at that concentration, not a potency): 99.7%
For compound 4 the middle estimate is 0.3 percentage points above the measured one; low and high end bracket the measured number.
By their numbers in this assay, from the lowest: compounds 4, 1, 2 and 3 (each within the scatter of the next).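

In this assay the step for chloro in place of hydrogen on an aromatic carbon reads a number 0.3 percentage points lower from compound 3 to compound 4 (within the scatter). This is the first single-point step shown that adds a heavy atom to the shared core, whereas the earlier step only exchanged pyridin-2-yl for pyridin-3-yl. It shows that a chloro at this place, next to the ring nitrogen and ortho to a large group, keeps compound 4 within the scatter of compound 3, and nothing measured here offers an explanation for that outcome.

With all four compounds within the scatter of one another in this assay, the compounds shown do not reveal which change at this place, if any, would shift the read-out. An amine, a carboxylic acid or a longer chain at the same ring carbon remains an open question.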